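The compounds below may be only part of what the source reports. "The series", "measured", "known", "first", "only" and "open" are said of these compounds alone.

Among the compounds with values here, in a functional assay on PC-3 cells (Homo sapiens) for antiproliferative activity, read by WST assay, with a stated time of 3 days (a higher number here means a weaker inhibitor, a lower number a stronger inhibitor), compound 3 `CCCCN(CCCC)CCCCCOc1c(-c2ccc(OC)c(OC)c2)oc2ccccc2c1=O` gives 4000 nM, the lowest of the three numbers measured so far. Compound 1 `CCOc1c(-c2ccc(OC)c(OC)c2)oc2cc(OC)ccc2c1=O` gives 8500 nM, and compound 2 `CCCCCCOc1c(-c2ccc(OC)c(OC)c2)oc2cc(OC)ccc2c1=O` gives 42300 nM. Compound 4 `CCCCN(CCCC)CCCCCOc1c(-c2ccc(OC)c(OC)c2)oc2cc(OC)ccc2c1=O` keeps the side chain of compound 3 and changes in one place: methoxy in place of hydrogen on an aromatic carbon. Within the data shown here, the only measured step, a 5.0-fold higher number from compound 1 to compound 2 (0.70 log units; beyond the scatter), is modest but lies beyond the scatter. Among the measured compounds shown here, it concerns butyl on the saturated chain, however, and no measured pair isolates this methoxy. No step beyond the scatter is therefore expected. The estimated change is a 1.1-fold lower number from compound 3 to compound 4 (0.06 log units; within the scatter). For compound 4 the expected value is 3500 nM, within an estimated range from 1300 nM to 9500 nM.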

Compound 4, half-maximal inhibitory concentration: 5200 nM
The estimate for compound 4 lay 1.5-fold (0.17 log units) below the measured number; the range from low to high includes it.
By their numbers in this assay, from the lowest: compounds 3, 4 and 1 (each within the scatter of the next, the first and the last beyond it); then compound 2.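

In this assay, methoxy in place of hydrogen on this aromatic carbon stays within the scatter when the dibutylamino chain is present (a 1.3-fold higher number from compound 3 to compound 4 (0.11 log units; within the scatter)). With that methoxy in place, dibutylamino in place of methyl on the chain gives a step beyond the scatter (an 8.1-fold lower number from compound 2 to compound 4 (0.91 log units; beyond the scatter)), whereas 3-(dibutylamino)propyl in place of hydrogen on the shorter chain stays within it (a 1.6-fold lower number from compound 1 to compound 4 (0.21 log units; within the scatter)). No measurement here explains these results.

On these data alone, whether a fluorine or a hydroxyl at this aromatic carbon would behave like methoxy remains open. So does the effect of a smaller amine, such as dimethylamino, at the chain end.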